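Working notes on compound 4 of the sulfide series

A few compounds are considered here, and "the series" means these few. Any claim that something is new, unique, unknown or untested is made for them only; others in the source may bear on it.

Compound 3 `C=CCSc1nnc(CCC)n1N1C(=O)c2ccccc2C1=O` is the reference point. In a functional assay on PC-3M cells (Homo sapiens) for cytotoxicity, read by MTT assay, with a stated time of 48 h (on this read-out lower numbers stand for stronger inhibition and higher numbers for weaker inhibition), compound 3 gives > 200000 nM, which is a limit of the assay and not a number. Compound 1 `C=CCSc1nnc(CC)n1N1C(=O)c2ccccc2C1=O` sits at the same boundary: in this assay compound 1 gives > 200000 nM, again a limit. Compound 2 `CCc1nnc(SCc2ccccc2)n1N1C(=O)c2ccccc2C1=O` completes the measured set; in this assay compound 2 gives > 200000 nM, also a limit. All three values share (the limit of > 200000 nM in this assay, at which 3 of the 3 values shown sit), so the step that the two limits leave unreadable from compound 1 to compound 2 and the step that the two limits leave unreadable from compound 1 to compound 3 cannot be read in size or direction.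

Compound 4 `CCCc1nnc(SCc2ccccc2Cl)n1N1C(=O)c2ccccc2C1=O` differs from compound 3 by 2-chlorophenyl in place of vinyl on a saturated chain carbon bound to a sulfur. The nearest measured step, a step that the two limits leave unreadable from compound 1 to compound 2, concerns phenyl in place of vinyl on a saturated chain carbon bound to a sulfur and gives no readable size. The chlorine has no measured counterpart among these compounds. With every compound shown at the boundary, compound 4 is expected to stay without a number as well, and the expected step of a number no higher from compound 3 to compound 4 (the limit leaves the size open) is one the limits would again hide. The estimate for compound 4 is 200000 nM, with an expected range of 60000 nM to 600000 nM, most likely returned as a limit.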

Compound 4, half-maximal inhibitory concentration: > 200000 nM
Compound 4 ended at the assay's limit; the forecaster's own chance of this, stated with the estimate: 80%; the middle value lies on the limit itself.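

Compound 4 adds no readable step: the step from compound 3 to compound 4 cannot be read in size or direction, because compound 1, compound 2, compound 3 and compound 4 all stand at one limit: the limit of > 200000 nM in this assay, at which 4 of the 4 values shown sit.

The compounds shown leave open whether any of these changes, 2-chlorophenyl included, alters the read-out at all.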